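Working notes on compound 4 in this cytotoxicity series

This account rests on a few compounds, and the source may have more. Where it says the series, first, only, none or still open, it means among the compounds named here.

Measured in an ADME assay on L02 cells (Homo sapiens) for cytotoxicity, read by MTT assay, with a stated time of 48 h; a higher number here means a weaker inhibitor, a lower number a stronger inhibitor:
compound 1 `COc1cc2ccc(=O)oc2cc1OCCOc1no[n+]([O-])c1S(=O)(=O)c1ccccc1` gives 10900 nM
compound 2 `COc1cc2ccc(=O)oc2cc1OCCCOc1no[n+]([O-])c1S(=O)(=O)c1ccccc1` gives 7820 nM
compound 3 `COc1cc2cc(NC(C)=O)c(=O)oc2cc1OCCOc1no[n+]([O-])c1S(=O)(=O)c1ccccc1` gives 10300 nM

Compound 3 holds the second highest of the three numbers, with compound 1 nearest and compound 2 furthest, and all three gaps lie within the scatter. Compound 4 `COc1cc2cc(N)c(=O)oc2cc1OCCOc1no[n+]([O-])c1S(=O)(=O)c1ccccc1` is not yet measured; it differs from compound 3 by hydrogen in place of acetyl on a nitrogen on an aromatic ring. Among the compounds with values here, the only measured step that touches this nitrogen is a 1.1-fold lower number from compound 1 to compound 3 (0.02 log units; within the scatter), which was within the scatter. Within the data shown here, no measured step removes the acetyl, so there is nothing to support a shift beyond the scatter in either direction. The step of a 1.0-fold lower number from compound 3 to compound 4 (0.01 log units; within the scatter) is therefore expected to stay within the scatter. For compound 4 the estimate is 10000 nM, with a range from 4000 nM to 25000 nM.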

Compound 4, half-maximal inhibitory concentration: 9820 nM
For compound 4 the middle estimate is 1.0-fold (0.01 log units) above the measured one; low and high end bracket the measured number.
By their numbers in this assay, from the lowest: compounds 2, 4, 3 and 1 (each within the scatter of the next).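

In this assay, a 1.0-fold lower number from compound 3 to compound 4 (0.02 log units; within the scatter) shows that the acetyl on this nitrogen can go without moving the read-out beyond the scatter, something compound 3 alone could not show. Amino in place of hydrogen on the aromatic carbon gives a 1.1-fold lower number from compound 1 to compound 4 (0.05 log units; within the scatter), so hydrogen, acetamido and amino at this place all read alike within the scatter. Nothing available bears on why these numbers agree.

Going by these compounds, whether a longer acyl chain or a carboxylic acid at this place would also stay within the scatter remains open. Also open, on these data alone, is whether amino in place of acetamido would read the same on the chain of compound 2.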